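The source may report more compounds than this note shows. Statements on the series, on what has been measured and on what is new or still open speak of the compounds shown alone.

In an ADME assay on cells (Hepatocyte, Rattus norvegicus) for pharmacokinetics, read by LC-MS, with a stated time of 90 min, tested at 1 uM (a lower number here means slower removal, a higher number faster removal of the compound), compound 3 (`COC(=O)N(Cc1cccc(F)c1)c1c(N)nc(-c2nn(Cc3ccccc3F)c3ncccc23)nc1N`) gives 53.3 mL/min/kg, within the scatter of compound 2 (`COC(=O)N(CCO)c1c(N)nc(-c2nn(Cc3ccccc3F)c3ncccc23)nc1N`) at 61.7 mL/min/kg and well above compound 1 (`CCN(C(=O)OC)c1c(N)nc(-c2nn(Cc3ccccc3F)c3ncccc23)nc1N`) at 11.7 mL/min/kg. Compound 4 (`COC(=O)Nc1c(N)nc(-c2nn(Cc3ccccc3F)c3ncccc23)nc1N`) has hydrogen in place of 3-fluorobenzyl on an amide-type nitrogen. Going by the values given here, no measured compound has hydrogen there, so the evidence is indirect. Changing the group on that nitrogen gave a 5.3-fold higher number from compound 1 to compound 2 (0.72 log units; beyond the scatter) and a 4.6-fold higher number from compound 1 to compound 3 (0.66 log units; beyond the scatter), both modest, whereas a 1.2-fold lower number from compound 2 to compound 3 (0.06 log units; within the scatter) stayed within the scatter. Compound 1 alone sits low, and the removal of the whole 3-fluorobenzyl group is expected to move the number towards it, with an estimated 2.7-fold lower number from compound 3 to compound 4 (0.43 log units; beyond the scatter). For compound 4 the expected value is 20 mL/min/kg, with an estimated range of 7 mL/min/kg to 55 mL/min/kg.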

Compound 4, clearance: 1.67 mL/min/kg
Compound 4: the middle estimate sits 12-fold (1.08 log units) above what was measured, outside the stated range (below it).
By their numbers in this assay, from the lowest: compound 4; then compound 1; then compounds 3 and 2 (each within the scatter of the next).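

In this assay compound 4 has the lowest number of the four: hydrogen on the amide-type nitrogen gives a 32-fold lower number from compound 3 to compound 4 (1.50 log units; beyond the scatter) and a 37-fold lower number from compound 2 to compound 4 (1.57 log units; beyond the scatter) as large steps, and a 7.0-fold lower number from compound 1 to compound 4 (0.85 log units; beyond the scatter) as a modest one. Even ethyl, the group of the lowest earlier compound, therefore goes with a higher number than hydrogen at this position. No measurement shown here accounts for these steps. The compounds shown leave open where methyl on this nitrogen would fall. They also leave open whether an amine on the ethyl chain would match the hydroxy of compound 2.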